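From cyclopentyl to 4-ethoxyphenyl on a shared core

The source may hold more compounds than are shown below. What is called first, only, known or untested is meant among the compounds shown, and "the series" means these compounds.

Compound 1 `O=C1C(NC2CCCC2)=CC(=O)c2c1nc1n2[C@H]2OC[C@@H](O)[C@H]2OC1` has not yet yielded a number. In a functional assay on ECa-109 cells for inhibition, with ECa-109 cell line (Homo sapiens) as the target, read by sulforhodamine B assay (on this read-out lower numbers stand for stronger inhibition and higher numbers for weaker inhibition), compound 1 gives > 16000 nM, which is a limit of the assay. Compound 2 `COc1ccc(NC2=CC(=O)c3nc4n(c3C2=O)[C@H]2OC[C@@H](O)[C@H]2OC4)cc1` is also known only by a limit, > 4000 nM in this assay. Neither compound therefore offers a measured potency or a step to build on.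

Compound 3 `CCOc1ccc(NC2=CC(=O)c3c(nc4n3[C@H]3OC[C@@H](O)[C@H]3OC4)C2=O)cc1` has 4-ethoxyphenyl in place of cyclopentyl on an amine nitrogen. With no number yet measured, only a small move toward stronger inhibition is expected in this assay, and the outcome may well be another limit. The expected change is an at least 2.2-fold lower number from compound 1 to compound 3 (0.35 log units; beyond the scatter). For compound 3, the estimated value is 7000 nM, with an expected range from 2000 nM to 20000 nM.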

Compound 3, half-maximal inhibitory concentration: > 4000 nM
Compound 3 gave a limit, no number (the forecaster's own chance of this, stated with the estimate: 65%); the middle value lies beyond the limit too.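

Compound 1 and compound 3 are both known in this assay only by limits, so the step between them cannot be read. The compounds shown leave open whether 4-ethoxyphenyl or cyclopentyl on the amine nitrogen gives stronger inhibition, and what measured potency the shared core can reach.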